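This account rests on a few compounds, and the source may have more. Where it says the series, first, only, none or still open, it means among the compounds named here.

Within the data shown here, compound 1 `COC(=O)Nc1cc(-c2cnc(OC[C@@](C)(N)CC(C)C)c(Cl)c2)ccn1` is one of two compounds measured in an assay on isolated protein for inhibition of Rho-associated protein kinase 2 (Homo sapiens); a lower number here means a stronger inhibitor, a higher number a weaker inhibitor; compound 1 gives 1100 nM, the higher of the two numbers. Compound 2 `COC(=O)Nc1cc(-c2cc(C)c(OC[C@@](C)(N)CC(C)C)cn2)ccn1` gives 780 nM in this assay, and the two values lie within the scatter of each other, so neither can be called the stronger inhibitor. Compound 3 `COC(=O)Nc1cc(-c2cnc(OC[C@@](C)(N)CC(C)C)c(C#N)c2)ccn1` has not yet been measured; it differs from compound 1 by cyano in place of chloro on an aromatic carbon. Among the measured compounds shown here, no measured pair shows what this change does, so only a shift no larger than the scatter, in no certain direction, is expected. Compound 3 is estimated at 900 nM, within 300 nM to 2700 nM, an expected step of a 1.2-fold lower number from compound 1 to compound 3 (0.09 log units; within the scatter).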

Compound 3, half-maximal inhibitory concentration: 1100 nM
Estimate against measurement, compound 3: 1.2-fold (0.09 log units) below; the range from low to high includes it.
By their numbers in this assay, from the lowest: compounds 2, 1 and 3 (each within the scatter of the next).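

In this assay, cyano in place of chloro on this aromatic carbon, ortho to the (2-amino-2,4-dimethylpentyl)oxy group, gives no change at the digits printed from compound 1 to compound 3 (within the scatter). Among these compounds, this is the first direct reading of a change at this position: one more heavy atom and a hydrogen-bond acceptor leave the number unmoved. Nothing measured here explains why these two groups read alike.

Going by these compounds, what a methoxy group, an amine or plain hydrogen on this carbon would do remains open. So does whether any group here can move the number beyond the scatter.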